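Working notes: adding nitro to compound 3

A few compounds are considered here, and "the series" means these few. Any claim that something is new, unique, unknown or untested is made for them only; others in the source may bear on it.

Measured so far:
- compound 1 `O=C(Nc1ccc(F)cc1)N1CCN(S(=O)(=O)c2sccc2-c2ccccc2Oc2ccc(O)c(O)c2)CC1`: 8100 nM
- compound 2 `COc1ccc(Oc2ccc(C(C)C)cc2-c2ccsc2S(=O)(=O)NCCNC(=S)Nc2cc(C(F)(F)F)cc(C(F)(F)F)c2)cc1OC`: 6900 nM
- compound 3 `O=S(=O)(c1sccc1-c1ccccc1Oc1ccc(O)c(O)c1)N1CCN(C(=S)Nc2cc(C(F)(F)F)cc(C(F)(F)F)c2)CC1`: 2200 nM

In a functional assay on HL-60 cells (Homo sapiens) for inhibition, read by CCK-8 assay, with a stated time of 48 h (on this read-out higher numbers stand for weaker inhibition and lower numbers for stronger inhibition), compound 3 gives the lowest of the three numbers, at 2200 nM. Compound 2 at 6900 nM and compound 1 at 8100 nM both lie higher, and each gap to compound 3 is beyond the scatter. Among the compounds with values here, the three measured compounds differ from one another in more than one place, so they offer no direct precedent for a single change.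

The next compound to be tested is compound 4 `O=[N+]([O-])c1ccc(Oc2ccc(O)c(O)c2)c(-c2ccsc2S(=O)(=O)N2CCN(C(=S)Nc3cc(C(F)(F)F)cc(C(F)(F)F)c3)CC2)c1`. It differs from compound 3 as follows: nitro in place of hydrogen on an aromatic carbon. The new nitro sits on an aromatic carbon, meta to a large group and para to a 3,4-dihydroxyphenoxy group.

Within the data shown here, with no single-change step to draw on, no step beyond the scatter is expected in this assay, with only a slight lean towards a lower number. The expected change is a 1.2-fold lower number from compound 3 to compound 4 (0.09 log units; within the scatter), and this remains an estimate resting on compound 3 at 2200 nM. The wide range below reflects the lack of any precedent. For compound 4 the estimated value is 1800 nM, with an expected range from 600 nM to 5500 nM.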

Compound 4, half-maximal inhibitory concentration: 8400 nM
Beside the measured number, compound 4's estimate is 4.7-fold (0.67 log units) below it; measured number above the stated range.
By their numbers in this assay, from the lowest: compound 3; then compounds 2, 1 and 4 (each within the scatter of the next).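

Nitro in place of hydrogen on this aromatic carbon, meta to a large group and para to a 3,4-dihydroxyphenoxy group, gives a 3.8-fold higher number from compound 3 to compound 4 (0.58 log units; beyond the scatter) in this assay. Within the data shown here, this is the first single-change step, and it shows that this position is not indifferent to substitution: here, adding nitro to the ring weakens inhibition by more than the scatter and gives up the advantage that compound 3 held as the lowest number among the earlier compounds. Nothing available explains the loss, and the step records only its direction and size on this one ring carbon.

One substituent at one position cannot show whether the loss is specific to nitro or follows from placing any group on this carbon; a fluorine atom, a methoxy group, an amine or a carboxylic acid at the same place would help to separate those two readings. Going by these compounds, whether nitro costs as much on other carbons of the same ring, or on the core of compound 2, also remains open.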